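Ethoxy to methyl: a half-life estimate in microsomes

The source may hold more compounds than are shown below. What is called first, only, known or untested is meant among the compounds shown, and "the series" means these compounds.

Measured in an in vitro ADME assay on microsomes from liver (Simiiformes); a higher number here means that the compound lasts longer, a lower number that the compound disappears faster:
Compound 1 `CC(=O)c1ccc(CCCOc2c(C)cc(-c3noc(C(F)(F)F)n3)cc2C)o1`: 1.05 h
Compound 2 `CCOc1cc(CCCOc2c(C)cc(-c3noc(C4CC4)n3)cc2C)on1`: > 2.5 h

The value for compound 2 in this assay is > 2.5 h, which is a limit of the assay and not a number. That places compound 2 at the limit of > 2.5 h in this assay, at which 1 of the 2 values shown sits. For the measured compounds named here, compound 1 and compound 2 differ in more than one place, so no measured step shows what a single change does here.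

Compound 3 `Cc1cc(CCCOc2c(C)cc(-c3noc(C4CC4)n3)cc2C)on1` is compound 2 with methyl in place of ethoxy on an aromatic carbon, so that 3-ethoxy-1,2-oxazol-5-yl becomes 3-methyl-1,2-oxazol-5-yl: methyl in place of ethoxy on an aromatic carbon.

Going by the values given here, compound 1 gives the only true number, 1.05 h, and the estimate leans on it. The estimate also leans on compound 2, whose value is a limit of the assay. A modest downward move is expected, one that may stay within the usual scatter of the assay. The expected change is an at least 1.5-fold lower number from compound 2 to compound 3 (0.19 log units; that floor lies within the scatter). For compound 3 the estimated half-life in this assay is 1.6 h, with an expected range of 0.7 h to 2.5 h.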

Compound 3, half-life: 2.23 h
Compound 3: middle estimate off by 1.4-fold (0.14 log units), on the low side; the range from low to high includes it.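

In this assay, for the compounds shown here, compound 3 gives 2.23 h, so a compound with methyl at this place, on an aromatic carbon next to the ring nitrogen, now has a true number for its half-life, which neither of the earlier compounds gave for this ring. Compound 2 gives > 2.5 h, which is a limit of the assay and not a number. This makes the single change readable for the first time, as an at least 1.1-fold lower number from compound 2 to compound 3 (0.04 log units; that floor lies within the scatter), but only as a floor, and the true size of the step cannot be told because one end of it is open: the limit of > 2.5 h in this assay, at which 1 of the 3 values shown sits.

The compounds shown leave open what other groups at this same place would do to the half-life, for instance a longer chain such as propoxy, an amine, or a plain hydrogen, any of which would show whether the half-life follows the size of the group or something else. They also leave open whether methyl in place of ethoxy would act in the same way on a different core, such as the core of compound 1.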